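The source may report more compounds than this note shows. Statements on the series, on what has been measured and on what is new or still open speak of the compounds shown alone.

Compound 3, `Cc1n[nH]c2nc(-c3ccc(NS(=O)(=O)c4cc(Cl)ccc4F)cc3)nc(OCC(CO)CO)c12`, holds the second highest of the three numbers recorded in an assay for inhibition of serine/threonine-protein kinase Sgk1 (Homo sapiens), with stated times of 30 min and 60 min, in the presence of a further agent that is not named here; a higher number here means a weaker inhibitor, a lower number a stronger inhibitor: compound 3 gives 2 nM. Its nearest neighbour is compound 2, `Cc1n[nH]c2nc(-c3ccc(NS(=O)(=O)c4cc(Cl)ccc4F)cc3)nc(OCC3(CN)COC3)c12`, which gives 1 nM; the gap between them, a 2.0-fold higher number from compound 2 to compound 3 (0.30 log units; within the scatter), sits within the scatter. Furthest away is compound 1, `CCOc1nc(-c2ccc(NS(=O)(=O)c3cc(Cl)ccc3F)cc2)nc2[nH]nc(C)c12`, with 183 nM. The two steps from compound 1 were large: a 180-fold lower number from compound 1 to compound 2 (2.26 log units; beyond the scatter) and a 92-fold lower number from compound 1 to compound 3 (1.96 log units; beyond the scatter). Each replaced a methyl on the chain carbon bound to the aromatic oxygen with a larger group carrying donors, and each brought a much lower number.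

Compound 4, `Cc1n[nH]c2nc(-c3ccc(NS(=O)(=O)c4cc(Cl)ccc4F)cc3)nc(OC3CCOCC3)c12`, differs from compound 3 by oxan-4-yl in place of 3-hydroxy-2-(hydroxymethyl)propyl on an oxygen on an aromatic ring. The two large steps tell that enlarging the group on this oxygen beyond methyl can lower the number greatly, while the step from compound 2 to compound 3 shows that the two donor-bearing groups gave numbers within scatter of each other. Among the compounds with values here, no measured step shows what happens when the donors are removed and a ring is put in their place. Compound 4 is therefore expected to give a higher number than compound 3, as a 10-fold higher number from compound 3 to compound 4 (1.00 log units; beyond the scatter), but to stay well below compound 1. The estimate for compound 4 in this assay is 20 nM, within a range from 4 nM to 100 nM.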

Compound 4, half-maximal inhibitory concentration: 14 nM
Beside the measured number, compound 4's estimate is 1.4-fold (0.15 log units) above it, within the range that was stated.
By their numbers in this assay, from the lowest: compounds 2 and 3 (each within the scatter of the next); then compound 4; then compound 1.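

In this assay, oxan-4-yl on this oxygen still gives a much lower number than the ethyl of compound 1 (a 13-fold lower number from compound 1 to compound 4 (1.12 log units; beyond the scatter)), so a group with no hydrogen-bond donors can capture a large part of the gain. It does not capture all of it, as the number rises against both donor-bearing groups (a 7.0-fold higher number from compound 3 to compound 4 (0.85 log units; beyond the scatter); a 14-fold higher number from compound 2 to compound 4 (1.15 log units; beyond the scatter)). Nothing shown gives a measured reason for these steps.

Because the change swaps an open chain with donors for a ring without them, these compounds cannot separate the loss of the hydroxyl groups from the arrival of the ring. On these data alone, a hydroxyl or an amine on the oxan-4-yl ring, or an open ether chain such as 2-methoxyethyl, remains open here and could tell those two apart.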